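A hydroxy group added to compound 1

The source may hold more compounds than are shown below. What is called first, only, known or untested is meant among the compounds shown, and "the series" means these compounds.

Measured in a functional assay on A549 cells (Homo sapiens) for inhibition, read by sulforhodamine B assay; a lower number here means a stronger inhibitor of growth, a higher number a weaker inhibitor of growth:
- compound 1 `COc1ccc(-c2ccc(-c3ccc(-c4nc5ccccc5[nH]4)cc3)cc2)cc1`: 38100 nM
- compound 2 `Clc1cccc(-c2ccc(-c3ccc(-c4nc5ccccc5[nH]4)cc3)cc2)c1`: 31100 nM

Only these two values are known so far, and they cannot be told apart, so compound 1 stands level with compound 2. Among the compounds with values here, the single measured step, a 1.2-fold lower number from compound 1 to compound 2 (0.09 log units; within the scatter), puts 3-chlorophenyl in place of 4-methoxyphenyl.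

Compound 3 `COc1ccc(-c2ccc(-c3ccc(-c4nc5c(O)cccc5[nH]4)cc3)cc2)cc1` keeps the whole of compound 1 except for one change: hydroxy in place of hydrogen on an aromatic carbon. In words, this is hydroxy in place of hydrogen on an aromatic carbon.

Within the data shown here, no measured compound carries this change, so the data give no direct measure of its effect. Among the measured compounds shown here, the one measured step bears on it only loosely, since it concerns a different group in a different place. It does show that one structural change left the number within the scatter. In this assay a small step is therefore expected, probably no larger than the scatter, with only a slight and uncertain lean towards a lower number. The expected step is a 1.5-fold lower number from compound 1 to compound 3 (0.18 log units; within the scatter). For compound 3 the estimated value is 25000 nM, with an expected range of 8000 nM to 60000 nM.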

Compound 3, concentration for 50% growth inhibition: 7690 nM
Beside the measured number, compound 3's estimate is 3.3-fold (0.51 log units) above it, and the stated range ends above it.
By their numbers in this assay, from the lowest: compound 3; then compounds 2 and 1 (each within the scatter of the next).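

In this assay, hydroxy in place of hydrogen on an aromatic carbon of the fused ring system gives a 5.0-fold lower number from compound 1 to compound 3 (0.69 log units; beyond the scatter), the only step shown so far that lies beyond the scatter. The other step shown, which replaces 4-methoxyphenyl with 3-chlorophenyl, gives a 1.2-fold lower number from compound 1 to compound 2 (0.09 log units; within the scatter), so the number does not respond to every single change in the structure, while this position on the 1H-benzimidazol-2-yl group does respond to a small added group. No measurement shown here explains what lies behind this step.

A single group at a single position cannot reveal whether the gain belongs to hydroxy itself or would also come with methoxy, an amine or a carboxylic acid in the same place, nor whether hydroxy on another carbon of that ring would do the same. On these data alone, it also remains open whether the hydroxy step carries over to other compounds, such as one that pairs 4-hydroxy-1H-benzimidazol-2-yl with the 3-chlorophenyl group of compound 2.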